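Compound 1 to compound 4: methyl in place of cyano

The compounds below may be only part of what the source reports. "The series", "measured", "known", "first", "only" and "open" are said of these compounds alone.

In an ADME assay on MT4 cells (Homo sapiens) for cytotoxicity, read by MTT assay, with a stated time of 5 days (on this read-out higher numbers stand for lower toxicity in this test and lower numbers for higher toxicity in this test), compound 1 (`COc1cc(Oc2c(C)cc(C#N)cc2C)cc(Nc2ccc(C#N)cc2)n1`) gives > 147000 nM, which is a limit of the assay and not a number. Compound 1 thus stands at the limit of > 147000 nM in this assay, at which 1 of the 3 values shown sits.

Two further compounds have numbers: compound 2 (`Cc1cc(C)c(Oc2cc(Nc3ccc([N+](=O)[O-])cc3)[nH]c(=O)c2)c(C)c1`) gives 26000 nM and compound 3 (`Cc1cc(C)c(Oc2cc(Nc3ccc(C#N)cc3)[nH]c(=O)c2)c(C)c1`) gives 32000 nM. Among the measured compounds shown here, the only measured step is a 1.2-fold higher number from compound 2 to compound 3 (0.09 log units; within the scatter). It puts cyano in place of nitro on an aromatic carbon, at another place than the change considered here, so it bears on that change only indirectly.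

For the measured compounds named here, compound 4 (`COc1cc(Oc2c(C)cc(C)cc2C)cc(Nc2ccc(C#N)cc2)n1`) has no measurement yet. Its difference from compound 1 is methyl in place of cyano on an aromatic carbon. In words, this is methyl in place of cyano on an aromatic carbon, para to a large group. Going by the values given here, no measured step makes this change, and no measured step starts from compound 1.

The nearest guide is compound 3, which holds a methyl at that place on a different core and gives 32000 nM. On that basis, a move toward a lower number in this assay is expected, though the core difference keeps this uncertain. The expected change is an at least 2.4-fold lower number from compound 1 to compound 4 (0.38 log units; beyond the scatter). For compound 4 the estimate is 60000 nM, with an expected range from 20000 nM to 147000 nM.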

Compound 4, half-maximal cytotoxic concentration: 29000 nM
Compound 4: middle estimate off by 2.1-fold (0.32 log units), on the high side; the measured number falls inside the stated range.
By their numbers in this assay, from the lowest: compounds 2, 4 and 3 (each within the scatter of the next). At a limit, above all of these: compound 1.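

In this assay, among the compounds shown here, this position is not neutral: methyl in place of cyano, para to a large group and meta to two methyl groups, gives an at least 5.0-fold lower number from compound 1 to compound 4 (0.70 log units; beyond the scatter) and is the first direct reading of this change. Swapping one small substituent on the aromatic carbon is enough to move the read-out toward higher toxicity in this test, with the rest of the core of compound 1 unchanged. The direction of the step is firm, but its size is only a lower bound, because compound 1 gives a limit of the assay and not a number: (the limit of > 147000 nM in this assay, at which 1 of the 4 values shown sits).

As far as these compounds go, only cyano and methyl have been compared at this place, so it remains open whether a chloro group, an amine, a carboxylic acid or a longer chain would sit nearer to compound 1 or to compound 4. It also remains open whether cyano in place of methyl at this position would give a similar step on the core of compound 3, since no such pair is among the compounds shown.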